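Cytotoxicity series: one-ring methoxy pattern on the amide chain

The source may hold more compounds than are shown below. What is called first, only, known or untested is meant among the compounds shown, and "the series" means these compounds.

Measured so far:
compound 1 `COc1ccc(/C=C/C(=O)Nc2cc(C(=O)c3cc(OC)c(OC)c(OC)c3)ccc2OC)cc1` — 10700 nM
compound 2 `COc1cc(C(=O)c2cc(OC)c(OC)c(OC)c2)cc(NC(=O)/C=C/c2cc(OC)c(OC)c(OC)c2)c1OC` — 2500 nM

In a functional assay on HeLa cells (Homo sapiens) for cytotoxicity, read by MTT assay, with a stated time of 72 h (a higher number here means a weaker inhibitor, a lower number a stronger inhibitor), compound 2 gives 2500 nM, the lower of the two numbers in hand. Compound 1 gives 10700 nM in this assay, a higher number that lies beyond the scatter of repeat measurements. The two compounds differ in more than one place, so no single step can be read from that pair.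

Compound 3 `COc1ccc(/C=C/C(=O)Nc2cc(C(=O)c3cc(OC)c(OC)c(OC)c3)cc(OC)c2OC)cc1` is not yet measured. It differs from compound 2 in one place: 4-methoxyphenyl in place of 3,4,5-trimethoxyphenyl on a double-bonded chain carbon bound to a double-bonded chain carbon. This is one of the changes that separates compound 2 from compound 1, while the rest of compound 2 is kept. A step toward a higher number is expected, of moderate size, since compound 1 with the same group on that chain carbon gives 10700 nM. For compound 3 the expected step is a 2.2-fold higher number from compound 2 to compound 3 (0.34 log units; beyond the scatter). Compound 3 is estimated at 5500 nM, within 2000 nM to 15000 nM.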

Compound 3, half-maximal inhibitory concentration: 11200 nM
Compound 3: the middle estimate sits 2.0-fold (0.31 log units) below what was measured, within the range that was stated.
By their numbers in this assay, from the lowest: compound 2; then compounds 1 and 3 (each within the scatter of the next).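

In this assay, the swap to 4-methoxyphenyl in place of 3,4,5-trimethoxyphenyl on a double-bonded chain carbon bound to a double-bonded chain carbon can now be read alone, as a 4.5-fold higher number from compound 2 to compound 3 (0.65 log units; beyond the scatter). Methoxy in place of hydrogen on an aromatic carbon gives a 1.0-fold higher number from compound 1 to compound 3 (0.02 log units; within the scatter), so of the two single changes now readable, only the swap on the chain lies beyond the scatter. No measured property bears on this result, and the step stands without an explanation.

The compounds shown hold only these two ring patterns on the chain, so it stays open how a 3,4-dimethoxyphenyl or a 4-aminophenyl group would fall relative to them. From the compounds shown here alone, it also stays open whether methoxy in place of hydrogen on an aromatic carbon would read the same with 3,4,5-trimethoxyphenyl on the chain.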